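The source may hold more compounds than are shown below. What is called first, only, known or untested is meant among the compounds shown, and "the series" means these compounds.

Measured compounds:
Compound 1 `CCCS(=O)(=O)Nc1ccc(F)c(C(=O)c2n[nH]c3ncc(-c4cccc(Cl)c4)cc23)c1F` — in an assay for binding affinity to dual specificity mitogen-activated protein kinase kinase 4 (Homo sapiens), read by KINOMEscan, tested at 100 nM (on this read-out lower numbers stand for a stronger effect and higher numbers for a weaker effect at the one concentration tested), compound 1 gives 40%.
Compound 2 `CCCS(=O)(=O)Nc1ccc(F)c(C(=O)c2n[nH]c3ncc(-c4ccccc4F)cc23)c1F` — in this assay compound 2 gives 2%.
Compound 3 `CCCS(=O)(=O)Nc1ccc(F)c(C(=O)c2n[nH]c3ncc(-c4ccc(C)c(C)c4)cc23)c1F` — in this assay compound 3 gives 20%.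

On these numbers compound 3 stands second highest of the three, between compound 2 and compound 1. The step from the first to it was a number 20 percentage points lower from compound 1 to compound 3 (beyond the scatter), and the step from the second to it was a number 18 percentage points higher from compound 2 to compound 3 (beyond the scatter). Compound 4 `CCCS(=O)(=O)Nc1ccc(F)c(C(=O)c2n[nH]c3ncc(-c4ccc(C(N)=O)cc4)cc23)c1F` is not yet measured. Its change from compound 3 is 4-carbamoylphenyl in place of 3,4-dimethylphenyl on an aromatic carbon. Every measured step swaps one ring for another at this same place and moves the number by a modest to large amount, in either direction, so swaps here are clearly felt. Within the data shown here, no measured step, however, brings in a group with a hydrogen-bond donor or acceptor, so nothing bears directly on the entering 4-carbamoylphenyl. The expectation is therefore a step of uncertain direction in this assay, centred near no change but with a wide range. The estimated step from compound 3 is a number 10 percentage points higher from compound 3 to compound 4 (within the scatter). For compound 4 the estimate is 30%, expected between 5% and 75%.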

Compound 4, a percentage reported as activity, at one concentration (the size of the read-out at that concentration, not a potency): 0.15%
Compound 4: the middle estimate sits 29.9 percentage points above what was measured; the whole stated range lies above it.
By their numbers in this assay, from the lowest: compounds 4 and 2 (each within the scatter of the next); then compound 3; then compound 1.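

In this assay, 4-carbamoylphenyl, the only ring at this place with a hydrogen-bond donor and acceptor, gives a stronger read-out than the 3,4-dimethylphenyl ring (a number 19.9 percentage points lower from compound 3 to compound 4 (beyond the scatter)) and the 3-chlorophenyl ring (a number 39.9 percentage points lower from compound 1 to compound 4 (beyond the scatter)). Against the 2-fluorophenyl ring there is no separation (a number 1.9 percentage points lower from compound 2 to compound 4 (within the scatter)), so two very differently substituted rings reach the same level, and a hydrogen-bond donor and acceptor on the ring is accommodated here but is not required to reach that level. No measurement at hand accounts for the differences among these rings.

From the compounds shown here alone, whether the carbamoyl group itself matters remains open, and a carboxylic acid or an aminomethyl group on the phenyl ring in its place would test that. A single concentration also leaves open whether compound 2 and compound 4 would differ in a full potency measurement.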